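Pyrimidinyl Sulfide in Place of Aminophenyl Sulfide

This account rests on a few compounds, and the source may have more. Where it says the series, first, only, none or still open, it means among the compounds named here.

Compound 1, `Nc1ccc(SCC(=O)Nc2ccc3nc(NC(=O)c4ccc(C(F)(F)F)cc4)sc3c2)cc1`: 1220 nM in a functional assay on U2OS cells (Homo sapiens) for antiproliferative activity, read by MTT assay, with a stated time of 72 h; on this read-out higher numbers stand for weaker inhibition and lower numbers for stronger inhibition
Compound 2, `O=C(CSc1cccc(O)c1)Nc1ccc2nc(NC(=O)c3cc(Cl)cc(Cl)c3)sc2c1`: 1530 nM
Compound 3, `Oc1ccc(Cl)cc1/C=N/c1ccc(-c2nc3ccccc3o2)c(O)c1`: 21700 nM

Among these three numbers compound 1 has the lowest; compound 2 sits within the scatter of it, while compound 3 lies far beyond it with a much higher number. Compound 4, `O=C(CSc1ncccn1)Nc1ccc2nc(NC(=O)c3ccc(C(F)(F)F)cc3)sc2c1`, has not yet been measured. It differs from compound 1 in one place: pyrimidin-2-yl in place of 4-aminophenyl on a sulfur. Within the data shown here, no step between measured compounds mirrors this change, so there is no measured guide to its size. With the shared core of compound 1 kept, a step of about the scatter is expected, if anything towards a higher number. Compound 4 is therefore estimated at 1800 nM in this assay, within 600 nM to 6000 nM. The expected step is a 1.5-fold higher number from compound 1 to compound 4 (0.17 log units; within the scatter).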

Compound 4, half-maximal inhibitory concentration: 28100 nM
Estimate against measurement, compound 4: 16-fold (1.19 log units) below; measured number above the stated range.
By their numbers in this assay, from the lowest: compounds 1 and 2 (each within the scatter of the next); then compounds 3 and 4 (each within the scatter of the next).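

In this assay, the group on the sulfur proves not to be freely exchangeable: pyrimidin-2-yl in place of 4-aminophenyl gives a 23-fold higher number from compound 1 to compound 4 (1.36 log units; beyond the scatter) with the rest of the structure unchanged. Among these compounds, the earlier compounds included no pair differing in one place, so this is the first measured sign of how strongly the number depends on this group. Nothing available here explains the size of this step.

Going by these compounds, whether the higher number goes with losing the amine or with the ring nitrogens remains open. A plain phenyl or a pyridin-2-yl on the same sulfur would help separate the two.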